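A few compounds are considered here, and "the series" means these few. Any claim that something is new, unique, unknown or untested is made for them only; others in the source may bear on it.

- Compound 1 `O=C(NNc1ccccc1Cl)c1ccc(NS(=O)(=O)c2cnc(O)nc2O)cc1` gives 7230 nM in a functional assay on OVCAR-3 cells (Homo sapiens) for antiproliferative activity, read by MTT assay, with a stated time of 24 h; on this read-out higher numbers stand for weaker inhibition and lower numbers for stronger inhibition
- Compound 2 `O=C(NNC(=O)c1cccc(Cl)c1)c1ccc(NS(=O)(=O)c2cnc(O)nc2O)cc1` gives 7710 nM in this assay
- Compound 3 `O=C(NNC(=O)c1ccc(NS(=O)(=O)c2cnc(O)nc2O)cc1)c1ccc(F)cc1` has not yet been measured

In this assay compound 2 stands at 7710 nM and lies within the scatter of compound 1. Compound 3 replaces 3-chlorophenyl with 4-fluorophenyl on a carbonyl carbon (4-fluorophenyl in place of 3-chlorophenyl on a carbonyl carbon). Going by the values given here, the one measured step is a 1.1-fold higher number from compound 1 to compound 2 (0.03 log units; within the scatter) and it bears only indirectly, since no measured compound carries 4-fluorophenyl. Given that small step, no shift beyond the scatter is expected in this assay in either direction. The expected change is a 1.0-fold lower number from compound 2 to compound 3 (0.02 log units; within the scatter) and no more. Compound 3 is estimated at 7400 nM with an expected range from 3500 nM to 15000 nM in this measurement.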

Compound 3, half-maximal inhibitory concentration: > 20000 nM
Compound 3 was reported as a limit; the forecaster's own chance of this, stated with the estimate: 3%; middle value at least 2.7-fold (0.43 log units) from the limit.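

Compound 3 reads > 20000 nM in this assay, which is a limit of the assay and not a number. Going by these compounds alone, the group on this carbonyl carbon therefore matters: 4-fluorophenyl in place of 3-chlorophenyl gives an at least 2.5-fold higher number from compound 2 to compound 3 (0.41 log units; beyond the scatter), the first change in this small set beyond the scatter from that compound. Starting instead from 2-chlorophenyl on an amine nitrogen, (4-fluorophenyl)carbonyl gives an at least 2.7-fold higher number from compound 1 to compound 3 (0.44 log units; beyond the scatter), whereas (3-chlorophenyl)carbonyl there had stayed within the scatter.

The compounds shown leave open whether the halogen or its place on the ring carries this step, a question that 4-chlorophenyl or 3-fluorophenyl on the same carbonyl carbon would separate. Going by these compounds, the true size of both steps also stays open.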